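This account rests on a few compounds, and the source may have more. Where it says the series, first, only, none or still open, it means among the compounds named here.

Compound 1, `CSc1ccc(C2=C(c3ccc(C)c(C)c3)C(=O)N3CCCC3C2)cc1`, gives 10000 nM in a functional assay on U-251 cells (Homo sapiens) for cytotoxicity; a higher number here means a weaker inhibitor of growth, a lower number a stronger inhibitor of growth.
Compound 2, `COc1ccc(C2=C(c3ccc(SC)cc3)CC3CCCN3C2=O)cc1`, gives 2000 nM in this assay.
Compound 3, `CSc1ccc(C2=C(c3ccc(O)cc3)C(=O)N3CCCC3C2)cc1`, gives only a limit of the assay, > 100000 nM, in this assay.

Among these, compound 1 stands with the highest of the two real numbers; the nearest measured compound is compound 2, with a 5.0-fold lower number from compound 1 to compound 2 (0.70 log units; beyond the scatter). Compound 3 sits at the limit of the assay, (the limit of > 100000 nM in this assay, at which 1 of the 3 values shown sits).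

The unmeasured compound 4, `CSc1ccc(C2=C(c3ccc(F)cc3)C(=O)N3CCCC3C2)cc1`, differs from compound 1 at a single point: 4-fluorophenyl in place of 3,4-dimethylphenyl on a double-bonded ring carbon.

Two measured steps leave the same group from the same place of the shared core. One is a 5.0-fold lower number from compound 1 to compound 2 (0.70 log units; beyond the scatter); the other is an at least 10-fold higher number from compound 1 to compound 3 (1.00 log units; beyond the scatter), which reaches the limit of the assay. These two steps pull in opposite directions, and between compound 2 and compound 3 lies an at least 50-fold higher number from compound 2 to compound 3 (1.69 log units; beyond the scatter). Neither step puts a 4-fluorophenyl group in the place that compound 4 fills, so there is no direct measurement of this change. For compound 4 the expected step is therefore small, no change at the digits printed from compound 1 to compound 4 (within the scatter), with no confident direction beyond the scatter. Compound 4 is estimated to give about 10000 nM in this assay, between 3000 nM and 40000 nM.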

Compound 4, concentration for 50% growth inhibition: 90 nM
Estimate against measurement, compound 4: 110-fold (2.05 log units) above, outside the stated range (below it).
By their numbers in this assay, from the lowest: compound 4; then compound 2; then compound 1. At a limit, above all of these: compound 3.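

The double-bonded ring carbon proves far more sensitive to the choice of aryl group than compounds 1 to 3 could show, since their numbers gave no sign that any group here could reach the potency seen in this assay with 4-fluorophenyl in place of 3,4-dimethylphenyl: a 110-fold lower number from compound 1 to compound 4 (2.05 log units; beyond the scatter). The single group on this phenyl ring also matters, as fluoro in place of methoxy gives a 22-fold lower number from compound 2 to compound 4 (1.35 log units; beyond the scatter), so the small fluoro group outperforms both the two-methyl pattern and the methoxy group among the compounds shown. Fluoro in place of hydroxy gives an at least 1100-fold lower number from compound 3 to compound 4 (3.04 log units; beyond the scatter), a step that rests on a limit of the assay for compound 3: the limit of > 100000 nM in this assay, at which 1 of the 4 values shown sits.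

The compounds shown leave open whether chloro, trifluoromethyl or an amine in the place of the fluoro would keep this potency, and whether a phenyl group carrying nothing there would lose it. They also cannot say why fluoro stands out, or whether its advantage would survive a change to the 4-(methylsulfanyl)phenyl group, for instance to a longer alkylsulfanyl chain.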